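Two-chloroalkyl purine analogues: growth inhibition and a deamination step

A few compounds are considered here, and "the series" means these few. Any claim that something is new, unique, unknown or untested is made for them only; others in the source may bear on it.

Measured so far:
compound 1 `Nc1nc(Cl)c2ncn(Cc3ccccc3CCl)c2n1` — 20900 nM
compound 2 `ClCc1ccc(Cn2cnc3c(Cl)nc(Cl)nc32)cc1` — 6920 nM

In a functional assay on SK-MEL-28 cells (Homo sapiens) for cytotoxicity, read by sulforhodamine B assay, with a stated time of 48 h (on this read-out higher numbers stand for weaker inhibition of growth and lower numbers for stronger inhibition of growth), compound 1 gives 20900 nM, the higher of the two numbers recorded; compound 2 gives 6920 nM, the lower, and the gap between them lies beyond the scatter of repeated measurements. Among the measured compounds shown here, no single-point step between the two measured compounds is available, as they differ in more than one place, so the comparison says only that compound 1 sits at the weaker end of the pair.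

Compound 3 `ClCc1ccccc1Cn1cnc2c(Cl)ncnc21` has not yet been measured in this assay. It differs from compound 1 by hydrogen in place of amino on an aromatic carbon: amino leaves and hydrogen enters, on an aromatic carbon of a six-membered aromatic ring with 2 nitrogen, between two ring nitrogen atoms, in the shared core. For the measured compounds named here, with no measured step of this type, the direction is uncertain; the step from compound 1 to compound 3 is expected to be small, a 1.2-fold higher number from compound 1 to compound 3 (0.08 log units; within the scatter), and may well remain within the scatter. Compound 3 is therefore estimated at 25000 nM, with a range from 8000 nM to 80000 nM.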

Compound 3, concentration for total growth inhibition: 5490 nM
Estimate against measurement, compound 3: 4.6-fold (0.66 log units) above, outside the stated range (below it).
By their numbers in this assay, from the lowest: compounds 3 and 2 (each within the scatter of the next); then compound 1.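

In this assay, among the compounds shown here, the replacement of amino by hydrogen on the aromatic carbon between two ring nitrogen atoms gives a 3.8-fold lower number from compound 1 to compound 3 (0.58 log units; beyond the scatter) and is the first step that changes one place only. It shows that the read-out responds to what sits at this position, with hydrogen going along with stronger inhibition of growth than amino in this pair, a modest change but one beyond the scatter. Nothing available explains this difference, and the pair alone gives no account of what the amino group or its removal does in the cells.

Going by these compounds, one pair gives a direction for one change on one background, so it sets no trend for this position, and how a methylamino group, a dimethylamino group, a methoxy group or a methyl group at the same carbon would read remains open. For the compounds shown here, also open is whether a step of this size would carry over to the substitution pattern of compound 2, which no single-place step yet connects to the other two compounds.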